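This account rests on a few compounds, and the source may have more. Where it says the series, first, only, none or still open, it means among the compounds named here.

Working notes on the series. In a functional assay on BJAB cells (Homo sapiens) for antiproliferative activity, with a stated time of 4 days (on this read-out higher numbers stand for an effect only at larger amounts of compound and lower numbers for an effect already at smaller amounts), compound 1 `COc1cc(-c2c(C)nn(-c3nc(-c4ccc(Cl)c(Cl)c4)c(SC(C)C)s3)c2C(=O)O)cc(C(F)(F)F)c1` gives 1380 nM and compound 3 `Cc1nn(-c2nc(-c3ccc(Cl)c(Cl)c3)c(SC(C)C)s2)c(C(=O)O)c1-c1cccc(F)c1` gives 900 nM. Compound 2 `Cc1c(-c2cc(Cl)cc(Cl)c2)c(C(=O)O)nn1-c1nc(-c2cnn(C)c2)c(SC(C)C)s1`, which carries a different group on the other end of the shared core, is reported in this assay as "not active" (no number reported). On the numbers shown, compound 3 has the lowest value of the two reported, with compound 1 nearest; the step of a 1.5-fold lower number from compound 1 to compound 3 (0.19 log units; within the scatter) is within the scatter, so the two cannot be ordered against each other.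

Compound 4 `Cc1nn(-c2nc(-c3ccc(Cl)c(Cl)c3)c(SC(C)C)s2)c(C(=O)O)c1-c1cncc(C#N)c1` is not yet measured. It differs from compound 3 in one place: 5-cyanopyridin-3-yl in place of 3-fluorophenyl on an aromatic carbon. The only measured step at this position is the one from compound 1 to compound 3, and it did not move the number beyond the scatter, so the aryl group at this position appears tolerant to exchange within the two examples shown; compound 2 offers no guidance here, since its change sits elsewhere. Among the measured compounds shown here, no measured step covers a change from a carbon-only ring to a ring with one hetero atom and a nitrile at this position.

For compound 4 a step of a 1.7-fold higher number from compound 3 to compound 4 (0.22 log units; within the scatter) in this assay is expected, within or near the scatter. The estimate for compound 4 is 1500 nM, with a range from 500 nM to 5000 nM.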

Compound 4, half-maximal effective concentration: 20000 nM
Compound 4: the middle estimate sits 13-fold (1.12 log units) below what was measured; the whole stated range lies below it.
By their numbers in this assay, from the lowest: compounds 3 and 1 (each within the scatter of the next); then compound 4.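

In this assay this position, on an aromatic carbon of the five-membered ring, proves less tolerant than the earlier pair suggested: 5-cyanopyridin-3-yl in place of 3-fluorophenyl gives a 22-fold higher number from compound 3 to compound 4 (1.35 log units; beyond the scatter), and in place of 3-methoxy-5-(trifluoromethyl)phenyl it gives a 14-fold higher number from compound 1 to compound 4 (1.16 log units; beyond the scatter), whereas a 1.5-fold lower number from compound 1 to compound 3 (0.19 log units; within the scatter) stayed within the scatter. The two aryl groups with a carbon-only ring therefore remain together, while the ring with one hetero atom and a nitrile stands apart from both, so the earlier tolerance holds only for compound 1 and compound 3. Nothing measured here bears on the reason for this step.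

As far as these compounds go, the ring nitrogen and the nitrile enter together in compound 4, so it remains open whether one of them alone accounts for the step, a question that pyridin-3-yl and 3-cyanophenyl at this position could separate. Also open, from the compounds shown here alone, is how other groups on this ring, such as an amine or a carboxylic acid, would read out, and whether the step would carry over to a different group at the other end of the shared core.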